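A few compounds are considered here, and "the series" means these few. Any claim that something is new, unique, unknown or untested is made for them only; others in the source may bear on it.

Compound 1 `O=C(NCc1ccccc1)c1cc(Oc2cccc(NC(=S)Nc3cccc(C(F)(F)F)c3)c2)ccn1` and compound 3 `O=C(NCc1ccccc1)c1cc(Oc2cccc(NC(=S)Nc3ccc(OC(F)(F)F)cc3)c2)ccn1` share a core and differ only in 4-(trifluoromethoxy)phenyl in place of 3-(trifluoromethyl)phenyl on an amide-type nitrogen. In a functional assay on HCT-116 cells (Homo sapiens) for cytotoxicity, read by MTT assay, with a stated time of 48 h (a lower number here means a stronger inhibitor, a higher number a weaker inhibitor), compound 1 gives 7500 nM, while compound 3 gives 7400 nM; the step is a 1.0-fold lower number from compound 1 to compound 3 (0.01 log units; within the scatter). Compound 2 `O=C(c1cc(Oc2cccc(NC(=S)Nc3cccc(C(F)(F)F)c3)c2)ccn1)N1CCCC1` differs from compound 1 by pyrrolidin-1-yl in place of benzylamino on a carbonyl carbon, and in this assay compound 2 gives 19200 nM, a step of a 2.6-fold higher number from compound 1 to compound 2 (0.41 log units; beyond the scatter). Compound 4 `O=C(c1cc(Oc2cccc(NC(=S)Nc3ccc(OC(F)(F)F)cc3)c2)ccn1)N1CCCC1` carries the same change on the core of compound 3, (pyrrolidin-1-yl in place of benzylamino on a carbonyl carbon), at an identical place, so the two steps are directly comparable. For compound 4 a step of a 2.6-fold higher number from compound 3 to compound 4 (0.41 log units; beyond the scatter) in this assay is expected, matching the earlier step. Within the data shown here, this rests on compound 3 standing at 7400 nM and on the only precedent, which read a 2.6-fold higher number from compound 1 to compound 2 (0.41 log units; beyond the scatter). Compound 4 is therefore estimated at 19000 nM, with a range from 9000 nM to 40000 nM.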

Compound 4, half-maximal inhibitory concentration: 17800 nM
The estimate for compound 4 lay 1.1-fold (0.03 log units) above the measured number; the measured number falls inside the stated range.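

In this assay, pyrrolidin-1-yl in place of benzylamino on the carbonyl carbon carries over to the second core, where the new reading is a 2.4-fold higher number from compound 3 to compound 4 (0.38 log units; beyond the scatter) and agrees with the earlier step: the same change on two cores in this assay, a 2.6-fold higher number (0.41 log units; beyond the scatter) from compound 1 to compound 2 and a 2.4-fold higher number (0.38 log units; beyond the scatter) from compound 3 to compound 4, 1.1-fold (0.03 log units) apart, within the scatter of two such steps. The aryl change on the amide-type nitrogen also gives a 1.1-fold lower number from compound 2 to compound 4 (0.03 log units; within the scatter) on the pyrrolidin-1-yl compounds and reads alike on both cores: the same change on two cores in this assay, a 1.0-fold lower number (0.01 log units; within the scatter) from compound 1 to compound 3 and a 1.1-fold lower number (0.03 log units; within the scatter) from compound 2 to compound 4, 1.1-fold (0.03 log units) apart, within the scatter of two such steps. These four compounds show that the two changes behave independently in this cytotoxicity read-out, but they do not show that this holds on other cores or why the number rises.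

Still open, from the compounds shown here alone, is whether morpholin-4-yl or dimethylamino on the carbonyl carbon follows the same step. Also open, going by these compounds, is how a nitrile or methoxy group on the phenyl ring at the amide-type nitrogen would read.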